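Carbamoyl to methoxycarbonyl in the series

The compounds below may be only part of what the source reports. "The series", "measured", "known", "first", "only" and "open" are said of these compounds alone.

Values in a functional assay on QG-56 cells (Homo sapiens) for antiproliferative activity; a lower number here means a stronger inhibitor, a higher number a weaker inhibitor:
- compound 1 `COc1cccc(-c2cc(CN(C)C)cc3cc(C(O)(c4ccc(C#N)cc4)c4cncn4C)oc23)c1`: 142 nM
- compound 2 `COc1cccc(-c2cc(C(N)=O)cc3cc(C(O)(c4ccc(C#N)cc4)c4cncn4C)oc23)c1`: 8.2 nM

Compound 2 holds the lower of the two numbers, and its gap to compound 1 lies beyond the scatter. Compound 3 `COC(=O)c1cc(-c2cccc(OC)c2)c2oc(C(O)(c3ccc(C#N)cc3)c3cncn3C)cc2c1` differs from it in one group: methoxy in place of amino on a carbonyl carbon. This is methoxy in place of amino on a carbonyl carbon, or carbamoyl to methoxycarbonyl.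

For the measured compounds named here, only one measured step bears on this, and only indirectly: a 17-fold lower number from compound 1 to compound 2 (1.24 log units; beyond the scatter), a large step with carbamoyl in place of (dimethylamino)methyl on an aromatic carbon. Going by the values given here, no measured pair tests the change at the carbonyl carbon itself. Compound 3 keeps the carbonyl that compound 1 lacks, so a step well short of that size is expected. A higher number is the likelier direction, with compound 2 at 8.2 nM the lowest so far, though the data do not settle this. The estimated change is a 2.4-fold higher number from compound 2 to compound 3 (0.39 log units; beyond the scatter). For compound 3 the expected value is 20 nM, with an estimated range of 6 nM to 70 nM.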

Compound 3, half-maximal inhibitory concentration: 36.3 nM
The estimate for compound 3 lay 1.8-fold (0.26 log units) below the measured number, and the stated range covers the measured number.
By their numbers in this assay, from the lowest: compound 2; then compound 3; then compound 1.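

At the carbonyl carbon in this assay, methoxy in place of amino gives a 4.4-fold higher number from compound 2 to compound 3 (0.65 log units; beyond the scatter), so the carbonyl alone does not carry the full result of compound 2, and the group on it matters. Methoxycarbonyl still improves on (dimethylamino)methyl on the aromatic carbon, with a 3.9-fold lower number from compound 1 to compound 3 (0.59 log units; beyond the scatter), so the series keeps part of the larger step of a 17-fold lower number from compound 1 to compound 2 (1.24 log units; beyond the scatter) without the amino group. No measurement in hand accounts for either difference.

Open, going by these compounds, is whether methylamino or dimethylamino on the same carbonyl carbon would stay near compound 2 or fall towards compound 3. Also open, on these data alone, is how a carboxylic acid at this carbonyl carbon, or a longer chain in place of the methoxy, would compare with these two compounds.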